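Cyano for methyl, carried to a second core

The compounds below may be only part of what the source reports. "The series", "measured", "known", "first", "only" and "open" are said of these compounds alone.

Measured in a functional assay for antagonist activity at Alpha-1A adrenergic receptor (Oryctolagus cuniculus); a lower number here means tighter binding, a higher number weaker binding:
compound 1, `CN(C)C(=O)c1cccnc1NCCCN1CCN(c2ccccc2C#N)CC1`, 2 nM
compound 2, `Cc1ccccc1N1CCN(CCCNc2ncccc2C(=O)N(C)C)CC1`, 2 nM
compound 3, `COc1cc(F)ccc1N1CCN(CCCNc2c(C(=O)N(C)C)cnc3c(C)cccc23)CC1`, 7.94 nM

Compound 2 and compound 1 differ by cyano in place of methyl on an aromatic carbon, and the step of no change at the digits printed from compound 2 to compound 1 (within the scatter). The core of compound 3 differs from the core of compound 2; that difference is not broken down here. Compound 3 stands highest of the three numbers, beyond the scatter from compound 1 and from compound 2.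

Compound 4, `COc1cc(F)ccc1N1CCN(CCCNc2c(C(=O)N(C)C)cnc3c(C#N)cccc23)CC1`, is not yet measured. It differs from compound 3 by cyano in place of methyl on an aromatic carbon. This is the same kind of change as that between compound 2 and compound 1, not the same: in compound 2 the methyl sits on a ring ortho to a large group, whereas in compound 3 it sits on a ring that is part of a fused or bridged system of two rings, ortho to a fused ring and meta to a fused ring. Within the data shown here, on the single precedent, the step from compound 3 to compound 4 in this assay is expected to be small, a 1.0-fold higher number from compound 3 to compound 4 (0.00 log units; within the scatter), resting on no change at the digits printed from compound 2 to compound 1 (within the scatter). Compound 4 is accordingly estimated at 8 nM, in a range from 3 nM to 20 nM.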

Compound 4, dissociation constant: 1.26 nM
For compound 4 the middle estimate is 6.3-fold (0.80 log units) above the measured one, and the stated range ends above it.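

In this assay, cyano in place of methyl on an aromatic carbon gives a 6.3-fold lower number from compound 3 to compound 4 (0.80 log units; beyond the scatter), whereas on the other core it gives no change at the digits printed from compound 2 to compound 1 (within the scatter). The size of this step therefore does not carry over unchanged from one core to the other in this series: the same change on two cores in this assay, no change at the digits printed (within the scatter) from compound 2 to compound 1 and a 6.3-fold lower number (0.80 log units; beyond the scatter) from compound 3 to compound 4, 6.3-fold (0.80 log units) apart, beyond the scatter of two such steps

Among these compounds, this comparison does not show what sets the two steps apart, since the core, the place of the methyl and the rest of the molecule all differ between the two pairs, and only one pair stands for each core, so neither step can be taken as typical of its core or extended to other compounds.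

Still open, on these data alone, is whether chloro, a carboxylic acid or a primary amide at the place held by cyano in compound 4 would give a step like that of cyano. Also open, as far as these compounds go, is whether the step from methyl to cyano on this core holds when the methoxy and fluoro groups of compound 4 are exchanged or the propyl chain is replaced by a longer chain.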